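Rewiring a Phenylamino Substituent on a Glutarimide-Bearing Core

A few compounds are considered here, and "the series" means these few. Any claim that something is new, unique, unknown or untested is made for them only; others in the source may bear on it.

Of the compounds shown here, three have been measured in an assay on FRT-Jurkat cells for inhibition of nuclear factor NF-kappa-B complex (Homo sapiens), read by flow cytometry, with a stated time of 24 h, tested at 10 uM; a lower number here means less inhibition, a higher number more inhibition at the concentration tested (going by the name of the read-out). Compound 1 `CN(c1ccccc1)c1ccc2c(c1)C(=O)N(C1CCC(=O)NC1=O)C2=O` gives -2%. Compound 2 `CC(C)c1ccc(Nc2cccc3c2C(=O)N(C2CCC(=O)NC2=O)C3=O)cc1` gives 19%, and compound 3 `CC(=O)c1ccc(Nc2cccc3c2C(=O)N(C2CCC(=O)NC2=O)C3=O)cc1` gives 2%. Compound 1 holds the lowest number of the three; its nearest neighbour is compound 3, whose value lies within the scatter of its own, while compound 2 stands beyond the scatter above it. Among the measured compounds shown here, the one step that can be traced within the measured set, acetyl in place of isopropyl on an aromatic carbon, gives a number 17 percentage points lower from compound 2 to compound 3 (beyond the scatter).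

Compound 4 `Cc1ccccc1Nc1ccc2c(c1)C(=O)N(C1CCC(=O)NC1=O)C2=O` has not yet been measured in this assay. It differs from compound 1 as follows: (2-methylphenyl)amino in place of methyl(phenyl)amino on an aromatic carbon. For the measured compounds named here, no measured step involves this kind of rearrangement; the step between compound 2 and compound 3 alters only a group on the distal ring and offers no direct guide. Compound 2 and compound 3, which both carry a hydrogen-bond donor on their amino linker, sit at or near the low end of the scale, as does compound 1. An estimated shift of a number 8 percentage points higher from compound 1 to compound 4 (within the scatter) is therefore expected, essentially none beyond the scatter. Compound 4 is expected to give 6%, with a range from -8% to 20%.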

Compound 4, a percentage reported as inhibition, at one concentration (the size of the read-out at that concentration, not a potency): 2%
Beside the measured number, compound 4's estimate is 4 percentage points above it; the range from low to high includes it.
By their numbers in this assay, from the lowest: compounds 1, 3 and 4 (each within the scatter of the next); then compound 2.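

In this assay, (2-methylphenyl)amino in place of methyl(phenyl)amino on the aromatic carbon of the core of compound 1 gives a number 4 percentage points higher from compound 1 to compound 4 (within the scatter). Among the compounds shown here, this is the first reading of a change at this position, and it shows that joining the same atoms differently, so that the entering group carries a hydrogen-bond donor the leaving group lacks, does not lift the read-out beyond the scatter at the concentration tested. Both compounds therefore stay at the low end of the scale, and nothing available explains why this change leaves the number where it is.

From the compounds shown here alone, what remains open is whether any group at this position can raise the number beyond the scatter, for instance a morpholine, a carboxylic acid or a longer chain such as a benzylamino group in place of the (2-methylphenyl)amino group. Also open, going by these compounds, is whether an isopropyl group on the outer ring of compound 4, in place of its methyl group, would give a number clearly higher than that of compound 4.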